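This account rests on a few compounds, and the source may have more. Where it says the series, first, only, none or still open, it means among the compounds named here.

Working notes on the series, read in a functional assay on Jurkat cells (Homo sapiens) for cytotoxicity, with a stated time of 72 h (a lower number here means that less compound is needed, a higher number that more compound is needed for the effect), throughout. Compound 1 (`C=C[C@@](C)(/C=C/c1ccc(O)cc1)CC/C=C/C(=O)OCc1ccccc1`) gives > 49000 nM as a limit of the assay, not a number. Compound 2 (`C=C[C@@](C)(/C=C/c1ccc(O)cc1)CC/C=C(C)/C=C/C(=O)OCc1ccccc1`) gives > 49000 nM as a limit too. Compound 3 (`C=C[C@@](C)(/C=C/c1ccc(O)c(CO)c1)CCC=C(C)C`) gives > 49000 nM as a limit as well. Compound 3 therefore has no number of its own, and the whole picture so far is the limit of > 49000 nM in this assay, at which 3 of the 3 values shown sit, with nothing to rank the three compounds. Within the data shown here, no measured step connects any of them, so no size of effect for a change on the shared core can be read from the data.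

The next compound is compound 4 (`C=C[C@@](C)(/C=C/c1ccc(O)c(/C=C/C(=O)OCC)c1)CCC=C(C)C`). The change from compound 3 is 2-(ethoxycarbonyl)ethenyl in place of hydroxymethyl on an aromatic carbon and it places 2-(ethoxycarbonyl)ethenyl on an aromatic carbon, ortho to a hydroxy group. The expected direction is toward a lower number, by a modest step, though this is a judgement from the structural change alone. Among the measured compounds shown here, the only anchor is compound 3 with its limit of > 49000 nM in this assay and no step to calibrate against. The estimated shift an at least 1.6-fold lower number from compound 3 to compound 4 (0.21 log units; that floor lies within the scatter) is expected to be small, and compound 4 may well stay at the limit. Compound 4 is estimated at 30000 nM with an expected range of 10000 nM to 60000 nM for now.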

Compound 4, half-maximal effective concentration: > 49000 nM
Compound 4: no number, only a limit; the forecaster's own chance of this, stated with the estimate: 50%; middle value at least 1.6-fold (0.21 log units) away from the limit.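

In this assay, compound 4 gives only a limit, as compound 3 does, so the step between compound 3 and compound 4 cannot be read. The compounds shown leave open how 2-(ethoxycarbonyl)ethenyl compares with hydroxymethyl on that aromatic carbon, and whether any change on the shared core gives a measurable number.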